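The source may report more compounds than this note shows. Statements on the series, on what has been measured and on what is new or still open speak of the compounds shown alone.

The shared core of compound 2 `CCOC(=O)[C@@H]1CCCN(S(=O)(=O)c2ccc(S(=N)(=O)N(CC)CC)cc2)C1` carries, on an aromatic carbon of its six-membered ring, a group of four carbon, two nitrogen, one oxygen and one sulfur atoms. In a functional assay on MIA PaCa-2 cells (Homo sapiens) for inhibition, read by MTT assay, with a stated time of 7 days (on this read-out lower numbers stand for stronger inhibition and higher numbers for weaker inhibition), compound 2 gives 2600 nM. Within the data shown here, only one other compound has been measured: compound 1 `CCOC(=O)[C@@H]1CCCN(S(=O)(=O)c2ccc(S(=O)(=O)N3CCCCC3)cc2)C1`, which in this assay gives 2900 nM, and the step of a 1.1-fold lower number from compound 1 to compound 2 (0.05 log units; within the scatter) shows that the two numbers cannot be told apart.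

Compound 3 `CCOC(=O)[C@@H]1CCCN(S(=O)(=O)c2ccc(S(=O)(=O)N(C)C)cc2)C1` is to be measured next. Its difference from compound 2 is a group of 6 heavy atoms (2 carbon, 1 nitrogen, 2 oxygen, 1 sulfur; no ring) in place of a group of 8 heavy atoms (4 carbon, 2 nitrogen, 1 oxygen, 1 sulfur; no ring), on an aromatic carbon. Among the measured compounds shown here, the one measured step that bears on this place, from compound 1 to compound 2, exchanged a ring-bearing group for an open-chain one at the same aromatic carbon and moved the number only within the scatter. Nothing else measured touches this position. The change from compound 2 to compound 3 is therefore expected to bring no step beyond the scatter in this assay, that is a 1.1-fold higher number from compound 2 to compound 3 (0.03 log units; within the scatter). Compound 3 is accordingly estimated at 2800 nM, with a range from 1300 nM to 6000 nM.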

Compound 3, half-maximal inhibitory concentration: 900 nM
For compound 3 the middle estimate is 3.1-fold (0.49 log units) above the measured one; the measured number lies below the stated range.
By their numbers in this assay, from the lowest: compound 3; then compounds 2 and 1 (each within the scatter of the next).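

In this assay this position, on an aromatic carbon para to a large group, proves sensitive to the change, which the earlier pair of compounds had not revealed: dimethylsulfamoyl in place of the group carried by compound 2 gives a 2.9-fold lower number from compound 2 to compound 3 (0.46 log units; beyond the scatter) in this comparison. Dimethylamino in place of piperidin-1-yl on a sulfonyl sulfur gives a 3.2-fold lower number from compound 1 to compound 3 (0.51 log units; beyond the scatter) and so shows that exchanging only the amine part on that sulfur, with the sulfonyl kept, is enough to move the number beyond the scatter, and compound 3 now stands apart from both compounds 1 and 2, which remain within the scatter of each other. No evidence at hand accounts for these steps.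

The compounds shown leave open how a diethylamino group on the same sulfonyl sulfur would compare, which would separate the effect of the amine part in compound 2 from that of its imino group on sulfur. They also leave open whether a methylamino group, an unsubstituted amino group or a morpholine ring at that sulfur would follow compound 3 or compound 1.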